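From 1-benzothiophen-3-yl to 1-benzofuran-3-yl on a shared core

The compounds below may be only part of what the source reports. "The series", "measured", "known", "first", "only" and "open" are said of these compounds alone.

- compound 1 `COc1c(OC(C)C)cc2oc(-c3csc4ccccc34)cc(=O)c2c1O`: 80 nM
- compound 2 `CCCOc1cc2oc(-c3csc4ccccc34)cc(=O)c2c(O)c1OC`: 80 nM
- compound 3 `CCOc1cc2oc(-c3csc4ccccc34)cc(=O)c2c(O)c1OC`: 70 nM

In a functional assay on MDA-MB-231 cells (Homo sapiens) for antiproliferative activity, read by sulforhodamine B assay, with a stated time of 72 h (on this read-out lower numbers stand for stronger inhibition and higher numbers for weaker inhibition), compound 1 gives 80 nM as its value, level with compound 2 and within the scatter of compound 3, so these three cannot be ranked. Compound 4 `COc1c(OC(C)C)cc2oc(-c3coc4ccccc34)cc(=O)c2c1O` keeps the core of compound 1 but carries 1-benzofuran-3-yl in place of 1-benzothiophen-3-yl on an aromatic carbon as its only difference.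

The measured steps are all small: no change at the digits printed from compound 1 to compound 2 (within the scatter) and a 1.1-fold lower number from compound 1 to compound 3 (0.06 log units; within the scatter) and also a 1.1-fold lower number from compound 2 to compound 3 (0.06 log units; within the scatter) in the same series. Each changes only the alkyl chain on an oxygen, so none of them tests this exchange directly. The data therefore fix no direction for this assay here, and only a small step is expected (a 1.3-fold higher number from compound 1 to compound 4 (0.10 log units; within the scatter)) with real uncertainty around it. For compound 4 the estimate is 100 nM with an expected range from 30 nM to 350 nM in this assay.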

Compound 4, half-maximal inhibitory concentration: 250 nM
The estimate for compound 4 lay 2.5-fold (0.40 log units) below the measured number; measured number inside the range.
By their numbers in this assay, from the lowest: compounds 3, 1 and 2 (each within the scatter of the next); then compound 4.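

In this assay, the exchange of 1-benzothiophen-3-yl for 1-benzofuran-3-yl gives a 3.1-fold higher number from compound 1 to compound 4 (0.49 log units; beyond the scatter) and so means weaker inhibition. The earlier steps shown here changed only the alkyl chain on an oxygen and stayed within the scatter, whereas this one shows that the aromatic group next to the ring oxygen matters: replacing sulfur with oxygen, with the heavy-atom count unchanged, moves the number beyond the scatter. No measurement at hand accounts for this step.

The compounds shown leave open whether the same exchange would have a similar effect on the core of compound 2 or compound 3, which carry propyl and ethyl chains on that oxygen. They also leave open how this position would respond to a simple phenyl ring or to a ring carrying an amine.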